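From nitro to amino: the step to compound 4

This account rests on a few compounds, and the source may have more. Where it says the series, first, only, none or still open, it means among the compounds named here.

Measured in a functional assay on HeLa cells (Homo sapiens) for inhibition, with a stated time of 48 h, tested at 50 uM; on this read-out higher numbers stand for more inhibition of growth at the one concentration tested and lower numbers for less inhibition of growth:
compound 1 `C=C[C@@](C)(/C=C/c1ccc(OC(=O)CC)cc1)CCC=C(C)C`: 48%
compound 2 `C=C[C@@](C)(/C=C/c1ccc(OC(=O)CCCCC)cc1)CCC=C(C)C`: 50%
compound 3 `C=C[C@@](C)(/C=C/c1ccc(O)c([N+](=O)[O-])c1)CCC=C(C)C`: 49%

In this assay the three numbers lie within the scatter of one another, and compound 3, at 49%, cannot be separated from the other two. Compound 4 `C=C[C@@](C)(/C=C/c1ccc(O)c(N)c1)CCC=C(C)C` differs from compound 3 by one change, ortho to a hydroxy group: amino in place of nitro on an aromatic carbon. For the measured compounds named here, the only measured step, a number 2 percentage points higher from compound 1 to compound 2 (within the scatter), lies elsewhere, on a saturated chain, and stays within the scatter. Going by the values given here, no measured step touches nitro or amino, so the support is thin, and no step beyond the scatter is expected, though with wide uncertainty. The expected step is a number 2 percentage points lower from compound 3 to compound 4 (within the scatter). For compound 4 the estimated value is 47%, within an expected range from 30% to 64%.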

Compound 4, percent growth inhibition at one concentration: 48%
Beside the measured number, compound 4's estimate is 1 percentage points below it, within the range that was stated.
By their numbers in this assay, from the lowest: compounds 1, 4, 3 and 2 (each within the scatter of the next).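

In this assay, amino in place of nitro on an aromatic carbon, ortho to a hydroxy group, gives a number 1 percentage points lower from compound 3 to compound 4 (within the scatter) and shows that this exchange leaves growth inhibition at the one concentration tested without a readable change. This is the first step shown at this position, where the earlier compounds offered only a step on a saturated chain. Nothing measured here bears on the reason for this result. Going by these compounds, whether an acetamide or a methoxy group on this aromatic carbon would separate from compound 3 stays open, as does the behaviour of compound 4 at other concentrations.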